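Swapping Sulfamoyl for Acetyl on a Biaryl Carbamate

The source may report more compounds than this note shows. Statements on the series, on what has been measured and on what is new or still open speak of the compounds shown alone.

Three carbamates share one core and differ only in a single group on the outer ring. Compound 1 `O=C(NC1CCCCC1)Oc1cccc(-c2cccc(F)c2)c1` carries fluoro and gives 96.6 nM in an assay on cell membranes for binding affinity to Fatty-acid amide hydrolase 1 (Rattus norvegicus); a higher number here means a weaker inhibitor, a lower number a stronger inhibitor. Compound 2 `O=C(NC1CCCCC1)Oc1cccc(-c2cccc(Oc3ccccc3)c2)c1` carries phenoxy and gives 420 nM in this assay. Compound 3 `NS(=O)(=O)c1cccc(-c2cccc(OC(=O)NC3CCCCC3)c2)c1` carries sulfamoyl and gives 26.5 nM in this assay, the lowest of the three numbers, with compound 1 nearest and compound 2 furthest. Compound 4 `CC(=O)c1cccc(-c2cccc(OC(=O)NC3CCCCC3)c2)c1` is the next step: acetyl in place of sulfamoyl on an aromatic carbon. The comparisons that bear on this are a 3.6-fold lower number from compound 1 to compound 3 (0.56 log units; beyond the scatter) and a 16-fold lower number from compound 2 to compound 3 (1.20 log units; beyond the scatter), both pointing to sulfamoyl as the best group so far. Acetyl gives up the hydrogen-bond donor counted for sulfamoyl, so a modest rise is expected, a 2.6-fold higher number from compound 3 to compound 4 (0.42 log units; beyond the scatter). Compound 4 is therefore estimated at 70 nM, within 30 nM to 200 nM.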

Compound 4, half-maximal inhibitory concentration: 9.1 nM
Compound 4: middle estimate off by 7.7-fold (0.89 log units), on the high side; the measured number lies below the stated range.
By their numbers in this assay, from the lowest: compound 4; then compound 3; then compound 1; then compound 2.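

In this assay, acetyl outdoes sulfamoyl on this aromatic carbon, with a 2.9-fold lower number from compound 3 to compound 4 (0.46 log units; beyond the scatter), so a low number here does not depend on the hydrogen-bond donor that sulfamoyl has and acetyl lacks. The distance to the other groups is wider still, with an 11-fold lower number from compound 1 to compound 4 (1.03 log units; beyond the scatter) and a 46-fold lower number from compound 2 to compound 4 (1.66 log units; beyond the scatter), which makes compound 4 the strongest inhibitor of the four. No measurement available here explains why acetyl does better.

Still open, going by these compounds, is whether a longer ketone such as propanoyl, or a carboxylic acid or an amine in this same place, would give a lower number than acetyl.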